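The source may report more compounds than this note shows. Statements on the series, on what has been measured and on what is new or still open speak of the compounds shown alone.

Measured so far in a functional assay for inhibition, with Homo sapiens as the target; a lower number here means that less compound is needed, a higher number that more compound is needed for the effect:
Compound 1 `CC(Cl)C(=O)Nc1ccc(C2=NNC(=O)CC2)cc1` gives 0.45 ug/mL 
Compound 2 `O=C1CCC(c2ccc(NC(=O)CCCCl)cc2)=NN1` gives > 46.4 ug/mL 

Among the measured compounds shown here, compound 1 at 0.45 ug/mL holds the only actual number so far. The entry for compound 2 at > 46.4 ug/mL is a limit of the assay and not a number.

Compound 3 `CC(Cl)C(=O)Nc1ccc(C2=NNC(=O)C(C)C2)cc1` carries methyl in place of hydrogen on a saturated ring carbon and otherwise matches compound 1. For the measured compounds named here, the one measured step is an at least 100-fold higher number from compound 1 to compound 2 (2.01 log units; beyond the scatter) and it is large, but it concerns 3-chloropropyl in place of 1-chloroethyl on a carbonyl carbon, not this ring carbon. Going by the values given here, it bears only indirectly: this assay can move strongly, but no measured step fixes the size or direction for the methyl. A modest move toward a lower number is expected, with wide uncertainty. The step expected is a 2.3-fold lower number from compound 1 to compound 3 (0.35 log units; beyond the scatter) as an estimate. Compound 3 is expected at 0.2 ug/mL with an estimated range of 0.04 ug/mL to 1 ug/mL for now.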

Compound 3, half-maximal effective concentration: 32.9 ug/mL
Beside the measured number, compound 3's estimate is 160-fold (2.22 log units) below it; the whole stated range lies below it.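

Compound 1 is not tolerant at the core: methyl in place of hydrogen on a saturated ring carbon gives a 73-fold higher number from compound 1 to compound 3 (1.86 log units; beyond the scatter) in this assay. The earlier step, an at least 100-fold higher number from compound 1 to compound 2 (2.01 log units; beyond the scatter), concerned only the chain on the carbonyl carbon, so this ring carbon is a second place in compound 1 where one change moves the number strongly, here by the addition of a single carbon. Compound 3 still gives a real number, so this step has a definite size, whereas the entry for compound 2 is a limit of the assay and not a number: the limit of > 46.4 ug/mL in this assay, at which 1 of the 3 values shown sits.

The compounds shown hold only hydrogen and methyl at this ring carbon, so the effect of an ethyl, a hydroxyl or a fluorine there stays open. From the compounds shown here alone, whether a methyl on the other saturated ring carbon would give a similar step also stays open.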